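A few compounds are considered here, and "the series" means these few. Any claim that something is new, unique, unknown or untested is made for them only; others in the source may bear on it.

Of the compounds shown here, three built on one shared core have been tested in a functional assay on MDA-MB-231 cells (Homo sapiens) for inhibition, read by sulforhodamine B assay, with a stated time of 48 h; a higher number here means a weaker inhibitor of growth, a lower number a stronger inhibitor of growth. Compound 1 `COc1ccc(NC(=O)Nc2n[nH]c3ccccc23)cc1` gives only a limit in this assay, > 100000 nM, so no number is known for it (the limit of > 100000 nM in this assay, at which 1 of the 3 values shown sits). Compound 2 `CCCCOc1ccc(NC(=O)n2nc(N)c3ccccc32)cc1` gives 13800 nM. Compound 3 `Nc1nn(C(=O)Nc2c(F)cccc2F)c2ccccc12` gives 98800 nM. Of the two numbers, compound 2 shows the lower one, and its gap to compound 3 lies beyond the usual scatter. Compound 4 `Nc1nn(C(=O)Nc2ccc(Cc3ccccc3)cc2)c2ccccc12` has not yet been measured in this assay; it differs from compound 2 by benzyl in place of butoxy on an aromatic carbon. Among the measured compounds shown here, no measured pair shows a change of this kind, so the expectation rests on compound 2 alone. The expected step of a 1.7-fold lower number from compound 2 to compound 4 (0.24 log units; within the scatter) is small, toward a lower number if any. Compound 4 is estimated at 8000 nM, with a range from 2000 nM to 40000 nM.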

Compound 4, concentration for 50% growth inhibition: 847 nM
Compound 4: the middle estimate sits 9.4-fold (0.98 log units) above what was measured, outside the stated range (below it).
By their numbers in this assay, from the lowest: compound 4; then compound 2; then compound 3. At a limit, above all of these: compound 1.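

In this assay, the group on this aromatic carbon, para to a large group, clearly matters: benzyl in place of butoxy gives a 16-fold lower number from compound 2 to compound 4 (1.21 log units; beyond the scatter), a change that compound 3 and compound 1 could not reveal. This single pair shows that a benzyl ring is compatible with stronger growth inhibition here, but it sets no general rule. Nothing measured here explains why the step is so large. From the compounds shown here alone, it remains open whether the ring or the loss of the oxygen matters more, which phenoxy or a plain pentyl chain at this place could help to separate. Going by these compounds, how an amine there would read is also open.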